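Changing the benzylamine aryl group on the shared core

The source may report more compounds than this note shows. Statements on the series, on what has been measured and on what is new or still open speak of the compounds shown alone.

Compound 1, `COc1cccc(CNCCCNc2ccnc3cc(Cc4ccccc4)ccc23)c1O`: 4200 nM
Compound 2, `COc1cccc(CNCCCNc2ccnc3cc(-c4ccc(C(F)(F)F)cc4)ccc23)c1O`: 32000 nM
Compound 3, `COc1ccc(-c2ccc3c(NCCCNCc4cc(F)ccc4OC)ccnc3c2)cc1`: 32000 nM

In a physicochemical assay for solubility, with a stated time of 18 h, at pH 7.4 (a lower number here means a less soluble compound, a higher number a more soluble compound), compound 3 stands level with compound 2 at the digits shown, and the two together give the highest numbers of the three. Compound 1 sits furthest away, with a lower number than compound 3, a gap beyond the scatter. Among the measured compounds shown here, the only step measured so far, a 7.6-fold higher number from compound 1 to compound 2 (0.88 log units; beyond the scatter), concerns the aromatic carbon of the core, not the benzylamine end. Compound 4, `COc1ccc(-c2ccc3c(NCCCNCc4cccc(OC)c4O)ccnc3c2)cc1`, differs from compound 3 by 2-hydroxy-3-methoxyphenyl in place of 5-fluoro-2-methoxyphenyl on a saturated chain carbon bound to an amine nitrogen. For the measured compounds named here, no measured step touches this position, so the expectation rests on compound 2 and compound 3 sharing the same high number despite differing there. Compound 4 is therefore expected to show no step beyond the scatter, no change at the digits printed from compound 3 to compound 4 (within the scatter), with an estimated value of 32000 nM, ranging from 14000 nM to 70000 nM.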

Compound 4, solubility: 32000 nM
For compound 4 middle estimate and measured number coincide at the digits printed, within the range that was stated.
By their numbers in this assay, from the lowest: compound 1; then compounds 2, 3 and 4 (each within the scatter of the next).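

In this assay, among the compounds shown here, the first measured change on a saturated chain carbon bound to an amine nitrogen gives no change at the digits printed from compound 3 to compound 4 (within the scatter), so 2-hydroxy-3-methoxyphenyl and 5-fluoro-2-methoxyphenyl are not told apart at this position. On the aromatic carbon, methoxy in place of trifluoromethyl gives no change at the digits printed from compound 2 to compound 4 (within the scatter), whereas 4-methoxyphenyl in place of benzyl gives a 7.6-fold higher number from compound 1 to compound 4 (0.88 log units; beyond the scatter). No measurement at hand explains these results.

Still open, on these data alone, is how a carboxylic acid or an amine on the aromatic ring at this position would read in this assay.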